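The source may report more compounds than this note shows. Statements on the series, on what has been measured and on what is new or still open speak of the compounds shown alone.

Measured compounds:
- compound 1 `CC(C)Cc1ccc2c(NCCCNCc3ccco3)ccnc2c1`; in an ADME assay for permeability, using PAMPA, with a stated time of 30 min, at pH 7.4 (a lower number here means that the compound crosses the layer more slowly, a higher number that the compound crosses the layer faster), compound 1 gives 23 10^-6 cm/s.
- compound 2 `COc1ccc(F)cc1CNCCCNc1ccnc2cc(Oc3cccc(N(C)C)c3)ccc12`; in this assay compound 2 gives 317 10^-6 cm/s.
- compound 3 `COc1cccc(CNCCCNc2ccnc3cc(Oc4cccc(N(C)C)c4)ccc23)c1O`; in this assay compound 3 gives 317 10^-6 cm/s.

Compound 2 stands level with compound 3 at the digits shown, the two together the highest of the three numbers; compound 1 lies furthest away, a good deal lower and beyond the scatter.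

For the measured compounds named here, the one measured step, no change at the digits printed from compound 2 to compound 3 (within the scatter), swaps the group on the saturated chain carbon bound to an amine nitrogen and leaves the number unchanged within the scatter.

Compound 4 `COc1ccc(F)cc1CNCCCNc1ccnc2cc(Oc3ccccc3OC)ccc12` is not yet measured. Its difference from compound 2: 2-methoxyphenyl in place of 3-(dimethylamino)phenyl on an oxygen on an aromatic ring. Going by the values given here, no measured pair varies the group on the aromatic oxygen, so nothing bears directly on this change; the only comparison at hand is the swap from compound 2 to compound 3, which changed nothing. On that basis no step beyond the scatter is expected, as a 1.1-fold lower number from compound 2 to compound 4 (0.05 log units; within the scatter).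

The estimate for compound 4 in this assay is 280 10^-6 cm/s, expected to fall between 150 10^-6 cm/s and 450 10^-6 cm/s.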

Compound 4, apparent permeability: 317 10^-6 cm/s
Beside the measured number, compound 4's estimate is 1.1-fold (0.05 log units) below it; measured number inside the range.
By their numbers in this assay, from the lowest: compound 1; then compounds 2, 3 and 4 (each within the scatter of the next).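

In this assay, for the compounds shown here, 2-methoxyphenyl in place of 3-(dimethylamino)phenyl on an oxygen on an aromatic ring gives no change at the digits printed from compound 2 to compound 4 (within the scatter), the only measured step that varies the group at this position. This pair shows that a ring bearing dimethylamino and a ring bearing methoxy read alike here, so the nitrogen of the group that leaves is not required to keep the number at this level, at least in the setting of compound 2. No supporting measurement is available to explain why the number holds.

Compound 1 at 23 10^-6 cm/s differs from compound 2 in more than one place, so its lower number cannot be assigned to any single group. From the compounds shown here alone, whether a carboxylic acid or a primary amine on this ring, or a plain alkyl chain in place of the ring on the oxygen, would move the number remains open.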